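Longer Alkyl Chains on a Shared Core: Cell Inhibition

This account rests on a few compounds, and the source may have more. Where it says the series, first, only, none or still open, it means among the compounds named here.

Compound 1, `CCc1cc2ccccc2nc1-c1cc(-c2ccccc2)no1`: > 100000 nM
Compound 2, `CCCc1cc2ccccc2nc1-c1cc(-c2ccccc2)no1`: 52500 nM
Compound 3, `CCCCc1cc2ccccc2nc1-c1cc(-c2ccc(C)cc2)no1`: > 100000 nM

All three were tested in a functional assay on A549 cells (Homo sapiens) for inhibition, read by MTT assay, with a stated time of 24 h; a lower number here means a stronger inhibitor, a higher number a weaker inhibitor. For compound 1 the value is a limit of the assay, not a number. For compound 3 the value is likewise only a limit. Compound 2 differs from compound 1 by methyl in place of hydrogen on a saturated chain carbon, two bonds along the chain from an aromatic carbon, and that step gives an at least 1.9-fold lower number from compound 1 to compound 2 (0.27 log units; that floor lies within the scatter). Compound 4, `CCCCCc1cc2ccccc2nc1-c1cc(-c2ccc(C)cc2)no1`, has not been measured; it differs from compound 3 by methyl in place of hydrogen on a saturated chain carbon, four bonds along the chain from an aromatic carbon. The difference between the core of compound 1 and the core of compound 3 is not broken down here. The change from compound 3 to compound 4 is the same kind of change as that from compound 1 to compound 2, but the methyl enters four bonds along the chain from an aromatic carbon rather than two. In this assay compound 4 is expected to show a step that the limit leaves unreadable from compound 3 to compound 4, an expectation resting on compound 3 sitting at the limit of > 100000 nM in this assay, at which 2 of the 3 values shown sit. The expected value for compound 4 is 120000 nM, most likely between 40000 nM and 400000 nM.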

Compound 4, half-maximal inhibitory concentration: > 100000 nM
Compound 4 gave a limit, no number; the forecaster's own chance of this, stated with the estimate: 70%; the middle value does not contradict the limit.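

Compound 3 and compound 4 each give only a limit of the assay, not a number, and the step between them cannot be read in this assay. As far as these compounds go, whether this added methyl changes inhibition at all remains open.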